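The compounds below may be only part of what the source reports. "The series", "measured", "known", "first", "only" and "open" are said of these compounds alone.

Compound 1 `CCCc1ccc(NC2=CC(=O)c3nc4n(c3C2=O)[C@H]2OC[C@@H](O)[C@H]2OC4)cc1`: in a functional assay on ECa-109 cells for inhibition, with ECa-109 cell line (Homo sapiens) as the target, read by sulforhodamine B assay (on this read-out higher numbers stand for weaker inhibition and lower numbers for stronger inhibition), compound 1 gives > 4000 nM, which is a limit of the assay and not a number.
Compound 2 `O=C1C(NC2CCCC2)=CC(=O)c2c1nc1n2[C@H]2OC[C@@H](O)[C@H]2OC1`: in this assay compound 2 gives > 16000 nM, again a limit of the assay.
Compound 3 `CCc1ccc(NC2=CC(=O)c3c(nc4n3[C@H]3OC[C@@H](O)[C@H]3OC4)C2=O)cc1`: in this assay compound 3 gives > 4000 nM, also a limit of the assay.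

Compound 1 thus stands at a limit in this assay, and the two further values shown are limits as well, so none of the three compounds can be ordered against the others. Where they sit is summed up by the limit of > 16000 nM in this assay, at which 1 of the 3 values shown sits, and by the limit of > 4000 nM in this assay, at which 2 of the 3 values shown sit. Within the data shown here, the only single-point step that can be drawn between measured compounds, a step that the two limits leave unreadable from compound 2 to compound 3, is left unreadable by the two limits, so its size is not known.

The compound still to be measured is compound 4 `CCOc1ccc(NC2=CC(=O)c3nc4n(c3C2=O)[C@H]2OC[C@@H](O)[C@H]2OC4)cc1`. It differs from compound 1 in one place: ethoxy in place of propyl on an aromatic carbon. Among the measured compounds shown here, no measured step bears on this exchange, and the one step that is drawn has no readable size. The expectation for this assay is therefore a step from compound 1 to compound 4 of a step that the limit leaves unreadable from compound 1 to compound 4, that is, nothing beyond the scatter, with a good chance that compound 4 also returns only a limit. Compound 4 is estimated at 8000 nM, in the range 2000 nM to 40000 nM.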

Compound 4, half-maximal inhibitory concentration: 3210 nM
Estimate against measurement, compound 4: 2.5-fold (0.40 log units) above; the range from low to high includes it.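

In this assay, compound 4 is the only one of the compounds shown that gives a number and not a limit, so this position on the aromatic ring can carry a group that brings the read-out into measurable range. The exchange keeps the count of heavy atoms and swaps one carbon for an oxygen that counts as a hydrogen-bond acceptor, and it amounts to an at least 1.2-fold lower number from compound 1 to compound 4 (0.09 log units; that floor lies within the scatter), so the true size of the change may be small or large and remains unsettled. The other values remain limits and give nothing to set compound 4 against: the limit of > 4000 nM in this assay, at which 2 of the 4 values shown sit.

Whether the oxygen or the chain length matters stays open, since neither methoxy, a longer chain such as propoxy, nor a hydroxyl group at this place stands among the compounds shown. The step between the two groups on the amine nitrogen cannot be read, so what an amine or a carboxylic acid on the aromatic ring would do, and how the group on that nitrogen contributes, also remains undecided.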